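Hexyl in place of anilino on the imine nitrogen

The compounds below may be only part of what the source reports. "The series", "measured", "known", "first", "only" and "open" are said of these compounds alone.

Measured so far:
compound 1, `C/C(=N\Nc1ccccc1)c1c(O)c2ccccc2oc1=O` — in an assay on isolated protein for inhibition of myosin-2 (Bos taurus), read by spectrophotometry, with a stated time of 24 min (a higher number here means a weaker inhibitor, a lower number a stronger inhibitor), compound 1 gives 27000 nM
compound 2, `C/C(=N\CCO)c1c(O)c2ccccc2[nH]c1=O` — in this assay compound 2 is reported only as a limit, >= 100000 nM

For the measured compounds named here, compound 1 therefore holds the only actual number in the set; the other entry sits at the limit of >= 100000 nM in this assay, at which 1 of the 2 values shown sits. Going by the values given here, compound 2 differs from compound 1 in more than one place, so no single-change step between measured compounds exists, and what the pair shows is only that one value is a number and the other a limit.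

Compound 3, `CCCCCC/N=C(\C)c1c(O)c2ccccc2oc1=O`, is not yet measured. It differs from compound 1 by hexyl in place of anilino on a double-bonded nitrogen. Among the compounds with values here, no measured step guides this change. The step from compound 1 to compound 3 is expected to be a 2.0-fold higher number from compound 1 to compound 3 (0.31 log units; beyond the scatter), toward weaker inhibition, with a real chance that only a limit is returned. Compound 3 is estimated at 55000 nM, within 15000 nM to 200000 nM.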

Compound 3, half-maximal inhibitory concentration: 2900 nM
The estimate for compound 3 lay 19-fold (1.28 log units) above the measured number, and the stated range ends above it.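

In this assay, for the compounds shown here, the first readable step appears at this position: a 9.3-fold lower number from compound 1 to compound 3 (0.97 log units; beyond the scatter), with hexyl in place of anilino on a double-bonded nitrogen. The number therefore responds to what sits on this nitrogen, and neither the six-membered aromatic ring nor the hydrogen-bond donor of anilino is needed on the core of compound 1 for inhibition to persist here. Compound 2 differs in more than one place and gives a limit rather than a number: the limit of >= 100000 nM in this assay, at which 1 of the 3 values shown sits.

Going by these compounds alone, the single swap removes the ring and the donor together, so the data cannot separate their contributions to the step. On these data alone, whether octyl, a shorter chain such as butyl, or an amine or a carboxylic acid at the end of the hexyl chain would lower or raise the number remains open.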